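A Longer Alkyl Chain on Compound 3

The compounds below may be only part of what the source reports. "The series", "measured", "known", "first", "only" and "open" are said of these compounds alone.

Compound 3 `C/C=C/C=C/C(=O)N[C@H](C(=O)NCCCCCCCCCCCCCC)[C@@H](C)O` is one of three close relatives tested in a functional assay on SW-620 cells (Homo sapiens) for cytotoxicity, read by MTT assay, with a stated time of 48 h; a higher number here means a weaker inhibitor, a lower number a stronger inhibitor. Compound 3 gives 200000 nM, level with compound 1 `CCCCCCCCCCCCCCNC(=O)[C@@H](NC(=O)c1ccco1)[C@@H](C)O`, which gives 200000 nM, while compound 2 `CCCCCCCCCCCCCCNC(=O)[C@@H](NC(=O)c1cccs1)[C@@H](C)O` gives 78400 nM. The step of no change at the digits printed from compound 1 to compound 3 (within the scatter) lies within the scatter, whereas a 2.6-fold higher number from compound 2 to compound 3 (0.41 log units; beyond the scatter) lies beyond it, so compound 3 shares the highest numbers of the three with compound 1. Compound 4 `C/C=C/C=C/C(=O)N[C@H](C(=O)NCCCCCCCCCCCCCCCCCC)[C@@H](C)O` differs from compound 3 by butyl in place of hydrogen on a saturated chain carbon, ten or more bonds along the chain from an amide-type nitrogen. Among the compounds with values here, none of the measured steps touches this chain; each of them alters only the group on the carbonyl carbon. Without a precedent, the expected step is a 1.3-fold lower number from compound 3 to compound 4 (0.12 log units; within the scatter), inside the scatter, so compound 4 is estimated at 150000 nM, with a range from 60000 nM to 300000 nM.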

Compound 4, half-maximal inhibitory concentration: 200000 nM
Beside the measured number, compound 4's estimate is 1.3-fold (0.12 log units) below it, within the range that was stated.
By their numbers in this assay, from the lowest: compound 2; then compounds 1, 3 and 4 (each within the scatter of the next).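

In this assay, within the data shown here, the step of no change at the digits printed from compound 3 to compound 4 (within the scatter) is the first one measured on the long chain rather than on the group at the carbonyl carbon. With butyl in place of hydrogen at this far point of the chain, the reading stays within the scatter, so this change does not separate the two compounds here. No supporting measurement explains this result. Still open, from the compounds shown here alone, are how a shorter chain, or a chain ending in an amine or a carboxylic acid, would read, and whether the same change would also leave compound 2, with its thiophen-2-yl group, within the scatter.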